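The compounds below may be only part of what the source reports. "The series", "measured", "known", "first", "only" and "open" are said of these compounds alone.

Three close relatives share one core. Within the data shown here, compound 1 `COC(=O)c1ccc(NCc2cncn2Cc2ccccc2C(C)(C)C)cc1-c1ccccc1` is the first of them; in a toxicity assay on NIH3T3 cells (Mus musculus) for cytotoxicity, read by resazurin assay (a lower number here means that less compound is needed, a higher number that more compound is needed for the effect), compound 1 has "not determined" (no result reported), so it adds nothing to the numbers. Compound 2 `COC(=O)c1ccc(NCc2cncn2Cc2cccc(Cl)c2)cc1-c1ccccc1` carries chloro on its benzyl ring. In this assay compound 2 gives > 10000 nM, which is a limit of the assay rather than a number. The readings stopped at the limit of > 10000 nM in this assay, at which 1 of the 2 values shown sits, and compound 2 sits exactly there. Among the measured compounds shown here, compound 2 thus stands at the edge of what the assay can report, with no single number and no other measured compound beside it.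

Compound 3 `COC(=O)c1ccc(NCc2cncn2Cc2cccc(C#N)c2)cc1-c1ccccc1` differs from compound 2 in one place: cyano in place of chloro on an aromatic carbon. The change sits on an aromatic carbon of a six-membered aromatic ring of carbon only, meta to a large group. For the measured compounds named here, no measured pair shows what this change does in this assay, so the step must be guessed. In this assay the step is expected to be a step that the limit leaves unreadable from compound 2 to compound 3, not beyond the scatter in either direction. This rests on compound 2 already lying at the limit of > 10000 nM in this assay, at which 1 of the 2 values shown sits. Compound 3 is accordingly estimated at 15000 nM, within a range from 8000 nM to 40000 nM, most probably reported again only as a limit.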

Compound 3, half-maximal effective concentration: > 10000 nM
Compound 3 ended at the assay's limit (the forecaster's own chance of this, stated with the estimate: 70%); the middle value does not contradict the limit.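

Compound 2 and compound 3 both end at a limit of this assay rather than at a number, so no step can be read between them; both stop at the same point: the limit of > 10000 nM in this assay, at which 2 of the 3 values shown sit. As far as these compounds go, what cyano in place of chloro does in this assay stays open, as does the concentration, if any, at which either compound would show an effect.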